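A few compounds are considered here, and "the series" means these few. Any claim that something is new, unique, unknown or untested is made for them only; others in the source may bear on it.

In a functional assay on HeLa cells (Homo sapiens) for cytotoxicity, read by MTT assay, with a stated time of 72 h (on this read-out lower numbers stand for stronger inhibition and higher numbers for weaker inhibition), compound 1 `Cn1ccc2c(Oc3ccc(NC(=O)c4cc5cccnc5n(-c5ccc(Br)cc5)c4=O)cc3)ncnc21` gives 43800 nM and compound 2 `Cn1ccc2c(Oc3ccc(NC(=O)c4cc5cccnc5n(-c5ccc(F)cc5)c4=O)cc3F)ncnc21` gives 4250 nM, the lower of the two numbers, with a gap beyond the scatter. Compound 3 `Cn1ccc2c(Oc3ccc(NC(=O)c4cc5cccnc5n(-c5ccc(C(F)(F)F)cc5Cl)c4=O)cc3F)ncnc21` differs from compound 2 in one place, carrying 2-chloro-4-(trifluoromethyl)phenyl in place of 4-fluorophenyl on an aromatic nitrogen. Going by the values given here, no measured pair isolates a change at this place, so the expectation is uncertain. In this assay, a small shift towards weaker inhibition, not clearly beyond the scatter, is expected, giving an expected 1.4-fold higher number from compound 2 to compound 3 (0.15 log units; within the scatter). Compound 3 is estimated at 6000 nM, with an expected range from 1500 nM to 25000 nM.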

Compound 3, half-maximal inhibitory concentration: 170000 nM
The estimate for compound 3 lay 28-fold (1.45 log units) below the measured number; measured number above the stated range.
By their numbers in this assay, from the lowest: compound 2; then compound 1; then compound 3.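

In this assay the group on the aromatic nitrogen matters strongly: 2-chloro-4-(trifluoromethyl)phenyl in place of 4-fluorophenyl brings a 40-fold higher number from compound 2 to compound 3 (1.60 log units; beyond the scatter) and thus much weaker inhibition. Going by these compounds alone, this is the first step that isolates this position, and it shows that not every substituted phenyl ring is tolerated equally there. Nothing measured here accounts for the size of this loss. On these data alone, the chlorine and the trifluoromethyl enter together, and how much each contributes stays open. So does the effect of a phenyl ring carrying an amine or a methoxy group at this position.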